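A 2-phenylethenyl replaces dimethylaminophenyl: expected Vero cytotoxicity

A few compounds are considered here, and "the series" means these few. Any claim that something is new, unique, unknown or untested is made for them only; others in the source may bear on it.

Compound 1 `CN(C)c1ccc(C2CC(c3cc4ccccc4o3)=NN2C(=O)c2ccncc2)cc1` gives > 210000 nM in an ADME assay on Vero cells (Chlorocebus sabaeus) for cytotoxicity, read by MTT assay, with a stated time of 72 h (on this read-out higher numbers stand for weaker inhibition and lower numbers for stronger inhibition), a limit and not a number.
Compound 2 `O=C(c1ccncc1)N1N=C(c2cc3ccccc3o2)CC1c1ccc(O)cc1` gives > 200000 nM in this assay, likewise a limit.

Compound 1 therefore stands only at a limit in this assay. For the measured compounds named here, the one measured step, a step that the two limits leave unreadable from compound 1 to compound 2, cannot be read because the limit of > 200000 nM in this assay, at which 1 of the 2 values shown sits, and the limit of > 210000 nM in this assay, at which 1 of the 2 values shown sits, both sit at limits. Compound 3 `O=C(c1ccncc1)N1N=C(c2cc3ccccc3o2)CC1/C=C/c1ccccc1` differs from compound 1 by 2-phenylethenyl in place of 4-(dimethylamino)phenyl on a saturated ring carbon. Going by the values given here, no measured step covers this change, so the expectation rests on the limit of compound 1 alone. Compound 3 is estimated at 200000 nM, between 50000 nM and 400000 nM. The expected step of an at least 1.0-fold lower number from compound 1 to compound 3 (0.02 log units; that floor lies within the scatter) is none beyond the scatter.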

Compound 3, half-maximal inhibitory concentration: > 212000 nM
Compound 3 gave a limit, no number; the forecaster's own chance of this, stated with the estimate: 70%; middle value at least 1.0-fold (0.02 log units) away from the limit.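

For the compounds shown here, compound 3 stands only at a limit in this assay, as do compound 1 and compound 2, so no step among them can be read. The compounds shown leave open whether exchanging these groups on the saturated ring carbon changes the read-out at all.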